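Coumarin ether series: triazole aryl swap, cytotoxicity on HL-60 cells

The source may hold more compounds than are shown below. What is called first, only, known or untested is meant among the compounds shown, and "the series" means these compounds.

The series shares a coumarin core carrying an ether at the same position. Compound 1 `C#CCOc1ccc2oc(=O)ccc2c1` bears a propargyl ether; in a functional assay on HL-60 cells (Homo sapiens) for cytotoxicity, read by MTT assay, with a stated time of 48 h (on this read-out lower numbers stand for stronger inhibition and higher numbers for weaker inhibition), compound 1 gives "not determined" (no result reported). Compound 2 `O=c1ccc2cc(OCc3cc(-c4ccc(Cl)cc4)no3)ccc2o1` links the core through an isoxazole to a 4-chlorophenyl group, and in this assay compound 2 gives 44600 nM, a weak result. Compound 3 `O=c1ccc2cc(OCc3cn(-c4ccccc4Cl)nn3)ccc2o1` links the core through a triazole to a 2-chlorophenyl group; in this assay compound 3 gives "not determined" (no result reported), so it stands nowhere on the scale, and a further entry in the series likewise lacks a single number. Compound 4 `COc1ccccc1-n1cc(COc2ccc3oc(=O)ccc3c2)nn1` is the next member to be measured in this assay.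

The change from compound 3 to compound 4 is methoxy in place of chloro on an aromatic carbon. Within the data shown here, no measured pair shows a step of this kind, so its size and direction cannot be read from the data; any shift beyond the scatter is an open question. Given that compound 2 shows 44600 nM as the only anchor, compound 4 is expected to give about 45000 nM, with a range from 12000 nM to 160000 nM.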

Compound 4, half-maximal inhibitory concentration: 55200 nM
The estimate for compound 4 lay 1.2-fold (0.09 log units) below the measured number, and the stated range covers the measured number.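

Among these compounds, compound 3 has no single number in this assay, so no step to compound 4 can be read from it, even with compound 4 at 55200 nM. From the compounds shown here alone, the effect of changing 2-chlorophenyl to 2-methoxyphenyl on this read-out remains open. No supporting data bear on this result.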